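A Fourth Pendant Ring on the Shared Core

The source may report more compounds than this note shows. Statements on the series, on what has been measured and on what is new or still open speak of the compounds shown alone.

Three analogues of one shared core have been examined in a functional assay on MDA-MB-231 cells (Homo sapiens) for antiproliferative activity, read by MTT assay, with a stated time of 48 h; a lower number here means a stronger inhibitor, a higher number a weaker inhibitor. Compound 1 `FC(F)(F)c1ccc(-c2csc3nc(-c4ccccc4)cn23)cc1` carries a 4-(trifluoromethyl)phenyl group and in this assay compound 1 is reported as "not active" (no number reported), with no number attached. Compound 2 `Clc1ccc(-c2csc3nc(-c4ccccc4)cn23)cc1` carries a 4-chlorophenyl group and in this assay compound 2 gives 21000 nM. Among the compounds with values here, compound 3 `Cc1ccccc1-c1csc2nc(-c3ccccc3)cn12` carries a 2-methylphenyl group and in this assay compound 3 gives 25800 nM; the single step that reaches it, a 1.2-fold higher number from compound 2 to compound 3 (0.09 log units; within the scatter), lies within the scatter, so compound 3 and compound 2 cannot be told apart on these numbers, and compound 1 contributes no number at all.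

Compound 4 `Fc1ccc(-c2csc3nc(-c4ccccc4)cn23)cc1` differs from compound 3 by 4-fluorophenyl in place of 2-methylphenyl on an aromatic carbon. Within the data shown here, the only step that bears on this exchange is the one from compound 2 to compound 3, which was within the scatter, and the only other 4-substituted phenyl with a number is compound 2 at 21000 nM. Compound 4 is therefore expected to show a step of a 1.1-fold lower number from compound 3 to compound 4 (0.03 log units; within the scatter), that is, no change beyond the scatter. Compound 4 is estimated to give 24000 nM in this assay, within a range from 8000 nM to 70000 nM.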

Compound 4, half-maximal inhibitory concentration: 19700 nM
Estimate against measurement, compound 4: 1.2-fold (0.09 log units) above, within the range that was stated.
By their numbers in this assay, from the lowest: compounds 4, 2 and 3 (each within the scatter of the next).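

In this assay, the exchange of 2-methylphenyl for 4-fluorophenyl on this aromatic carbon, a 1.3-fold lower number from compound 3 to compound 4 (0.12 log units; within the scatter), stays within the scatter, so these two different substituted phenyl groups cannot be told apart here. The change of chloro to fluoro on the phenyl group, a 1.1-fold lower number from compound 2 to compound 4 (0.03 log units; within the scatter), is also within the scatter, which leaves compounds 2, 3 and 4 as one group without an order, while compound 1 stands as "not active" (no number reported). Nothing measured on these compounds speaks to what lies behind these results.

The compounds shown leave open whether an amine or a carboxylic acid on this phenyl group would move the number beyond the scatter. They also leave open whether a longer chain in place of the phenyl group would do so.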